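Para-substituent series on the shared core: note toward compound 4

The source may report more compounds than this note shows. Statements on the series, on what has been measured and on what is new or still open speak of the compounds shown alone.

Measured so far:
compound 1 `CCOc1ccc(N/N=C2\CCC(C)n3c2ncc(C(=O)O)c3=O)cc1`, 1.6 umol/kg
compound 2 `Cc1ccc(N/N=C2\CCC(C)n3c2ncc(C(=O)O)c3=O)cc1`, 1.3 umol/kg
compound 3 `CC(=O)c1ccc(N/N=C2\CCC(C)n3c2ncc(C(=O)O)c3=O)cc1`, 9.5 umol/kg

All three share one core and differ only in the group on an aromatic carbon. In a functional assay on the whole organism for inhibition, with Rattus norvegicus as the target (on this read-out higher numbers stand for an effect only at larger amounts of compound and lower numbers for an effect already at smaller amounts), compound 1 gives 1.6 umol/kg and compound 2 gives 1.3 umol/kg; the step of a 1.2-fold lower number from compound 1 to compound 2 (0.09 log units; within the scatter) is within the scatter, so these two are not ordered. Compound 3 gives 9.5 umol/kg in this assay, the highest number of the three: the steps of a 5.9-fold higher number from compound 1 to compound 3 (0.77 log units; beyond the scatter) and a 7.3-fold higher number from compound 2 to compound 3 (0.86 log units; beyond the scatter) are both beyond the scatter.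

Compound 4 `CC1CC/C(=N\Nc2ccc(C3CC3)cc2)c2ncc(C(=O)O)c(=O)n21` is not yet measured in this assay. It differs from compound 3 as follows: cyclopropyl in place of acetyl on an aromatic carbon. For the measured compounds named here, two measured steps bear on this change, both pointing the same way: acetyl in place of ethoxy (a 5.9-fold higher number from compound 1 to compound 3 (0.77 log units; beyond the scatter)) and acetyl in place of methyl (a 7.3-fold higher number from compound 2 to compound 3 (0.86 log units; beyond the scatter)) each raised the number by a modest amount. Going by these compounds, removing acetyl again is therefore expected to lower the number by a step of similar size, back toward the values of compounds 1 and 2; whether cyclopropyl behaves like methyl and ethoxy is unknown here, which widens the range. The expected step is a 5.3-fold lower number from compound 3 to compound 4 (0.72 log units; beyond the scatter). Compound 4 is estimated at 1.8 umol/kg in this assay, with a range of 0.8 umol/kg to 4.5 umol/kg.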

Compound 4, dose for 50% inhibition: 41.1 umol/kg
Estimate against measurement, compound 4: 23-fold (1.36 log units) below; measured number above the stated range.
By their numbers in this assay, from the lowest: compounds 2 and 1 (each within the scatter of the next); then compound 3; then compound 4.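

In this assay, for the compounds shown here, the aromatic carbon para to a large group proves more sensitive than the earlier compounds indicated, and taking acetyl away does not by itself bring the number down: cyclopropyl in place of acetyl gives a 4.3-fold higher number from compound 3 to compound 4 (0.64 log units; beyond the scatter). Cyclopropyl also separates clearly from the two lowest members of the series, in place of methyl with a 32-fold higher number from compound 2 to compound 4 (1.50 log units; beyond the scatter) and in place of ethoxy with a 26-fold higher number from compound 1 to compound 4 (1.41 log units; beyond the scatter), so acetyl no longer marks the high end of the range at this position. Acetyl and cyclopropyl have the same count of heavy atoms, so that count alone does not set the number here, and a carbon-only group at this position is not enough to keep it low.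

Nothing available accounts for the rise with cyclopropyl. Open is whether the rise belongs to the three-membered ring or to branching at the attachment carbon, which isopropyl, a cyclobutyl ring or a longer chain at the same position would help to separate, and how an amine or a carboxylic acid there would fall relative to the four groups shown.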